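A few compounds are considered here, and "the series" means these few. Any claim that something is new, unique, unknown or untested is made for them only; others in the source may bear on it.

Working notes on the series. Two compounds have numbers in an assay (Canis lupus familiaris) for binding affinity to platelet-activating factor receptor (Homo sapiens), read by radioligand binding; on this read-out lower numbers stand for stronger inhibition and higher numbers for weaker inhibition. Compound 1 `COc1ccc(-c2ccc(C(=O)NCCCCc3cccnc3)cc2OC)cc1OC` gives 300 nM in this assay. Compound 2 `COc1ccc(-c2ccc(C(=O)N[C@H](C)CCCc3cccnc3)cc2[N+](=O)[O-])cc1OC` gives 200 nM in this assay. Of the two numbers shown, compound 2 gives the one at the low end, and compound 1 sits within the scatter of it, so nothing separates the pair beyond the usual spread. Compound 3 `COc1ccc(-c2ccc(C(=O)NCCCCc3cccnc3)cc2[N+](=O)[O-])cc1OC` is not yet measured in this assay. It differs from compound 2 in one place: hydrogen in place of methyl on a saturated chain carbon bound to an amide-type nitrogen and a saturated chain carbon. No step between measured compounds covers this change, and the two numbers shown give no guide to it, so the expectation is a small step from compound 2 to compound 3 in this assay, at most a modest rise and plausibly none beyond the scatter, written as a 1.5-fold higher number from compound 2 to compound 3 (0.18 log units; within the scatter). On that basis compound 3 is estimated at 300 nM in this assay, with a range from 100 nM to 900 nM.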

Compound 3, half-maximal inhibitory concentration: 200 nM
Compound 3: middle estimate off by 1.5-fold (0.18 log units), on the high side, within the range that was stated.
By their numbers in this assay, from the lowest: compounds 2, 3 and 1 (each within the scatter of the next).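

In this assay hydrogen in place of methyl on a saturated chain carbon bound to an amide-type nitrogen and a saturated chain carbon gives no change at the digits printed from compound 2 to compound 3 (within the scatter) and so does not separate 1-methyl-4-(pyridin-3-yl)butyl from 4-(pyridin-3-yl)butyl with the nitro group in place. Now that the chain is the same on both sides, nitro in place of methoxy on an aromatic carbon can also be read alone: it gives a 1.5-fold lower number from compound 1 to compound 3 (0.18 log units; within the scatter) and so does not separate these two groups on the unbranched chain. Nothing shown offers a reason for either result.

On these data alone, it remains open whether an ethyl or a hydroxyl on that chain carbon, or the opposite configuration there, would also leave the number within the scatter. The same holds for a longer chain than 4-(pyridin-3-yl)butyl, and for an amine or a carboxylic acid on the aromatic carbon.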